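Piperazine Tail on an Inactive Pyridine Nitrile

This account rests on a few compounds, and the source may have more. Where it says the series, first, only, none or still open, it means among the compounds named here.

Of the compounds shown here, three sharing one core have been measured in an assay on isolated protein for inhibition of cathepsin S (Homo sapiens), read by fluorescence; on this read-out lower numbers stand for stronger inhibition and higher numbers for weaker inhibition. Compound 1, `N#Cc1nccc(-c2ccc(OCCCO)c(C(F)(F)F)c2)n1`, gives 4.5 nM in this assay. Compound 2, `N#Cc1cccc(-c2ccc(OCCCO)c(C(F)(F)F)c2)n1`, gives 155 nM in this assay. Compound 3, `N#Cc1cc(-c2ccc(OCCCO)c(C(F)(F)F)c2)ccn1`, is reported only as "not active" (no number reported) in this assay, with no number attached, so its standing can be stated merely as weaker than what compound 1 and compound 2 show, without a measured distance to either.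

Compound 4, `CN1CCN(CCCOc2ccc(-c3ccnc(C#N)c3)cc2C(F)(F)F)CC1`, keeps the core of compound 3 and differs from it in one place: 4-methylpiperazin-1-yl in place of hydroxy on a saturated chain carbon, three bonds along the chain from an oxygen on an aromatic ring. The change sits at the far end of the chain, three bonds along the chain from an oxygen on an aromatic ring, while the nitrile-bearing ring of compound 3 is unchanged.

Among the compounds with values here, no measured pair in this set shows what such a tail exchange does to the read-out. Within the data shown here, the account therefore rests on the one fact available for compound 3, which is its absence of activity in this assay. For compound 4 the expectation is that the outcome stays on the weak side and that a limit rather than a number is the likelier report, with an estimated value of 20000 nM in this assay and a range from 1000 nM to 100000 nM.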

Compound 4, half-maximal inhibitory concentration: "not active" (no number reported)
No number was reported for compound 4; the estimate stays without a comparison.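

In this assay compound 3 and compound 4 are both reported as "not active" with no number, so no step can be read between them. No measured property bears on this result. The compounds shown leave open what 4-methylpiperazin-1-yl in place of hydroxy does where a compound gives a number, such as compound 1.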